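A few compounds are considered here, and "the series" means these few. Any claim that something is new, unique, unknown or untested is made for them only; others in the source may bear on it.

Compound 1 `CCN1CCN(CC(=O)Nc2nc3ccccc3[nH]2)CC1` and compound 2 `O=C(CN1CCN(c2ccccc2F)CC1)Nc1nc2ccccc2[nH]1` share one core and differ only at the amine nitrogen in the ring. In a functional assay, read by spectrophotometry, with a stated time of 30 min, tested at 25 ug/mL (a higher number here means a stronger effect of the compound at the concentration tested, a lower number a weaker effect), compound 1 gives 26.6%; in this assay compound 2 gives 18.8%. The step of a number 7.8 percentage points lower from compound 1 to compound 2 (within the scatter) stays within the scatter, so the two numbers cannot be ranked. Of the two numbers shown, compound 2 holds the lower one, the nearest being compound 1, within the scatter of it. Compound 3 `O=C(CN1CCN(c2ccccn2)CC1)Nc1nc2ccccc2[nH]1` is not yet measured and differs from compound 2 by pyridin-2-yl in place of 2-fluorophenyl on an amine nitrogen in a ring. Among the measured compounds shown here, one measured step bears on this place: the exchange between compound 1 and compound 2 at the same amine nitrogen in a ring moved the read-out no further than the scatter. For the measured compounds named here, no measured pair compares pyridin-2-yl with 2-fluorophenyl. On that single step, a number 1.2 percentage points higher from compound 2 to compound 3 (within the scatter) is expected to remain within the scatter. Compound 3 is estimated at 20%, with a range from 8% to 32%.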

Compound 3, a percentage reported as activity, at one concentration (the size of the read-out at that concentration, not a potency): 40.9%
Compound 3: middle estimate off by 20.9 percentage points, on the low side; measured number outside the range, above it.
By their numbers in this assay, from the lowest: compounds 2 and 1 (each within the scatter of the next); then compound 3.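

In this assay the amine nitrogen in a ring turns out to be a place where the substituent can matter: pyridin-2-yl in place of 2-fluorophenyl gives a number 22.1 percentage points higher from compound 2 to compound 3 (beyond the scatter) and pyridin-2-yl in place of ethyl gives a number 14.3 percentage points higher from compound 1 to compound 3 (beyond the scatter) as the second comparison at this place. The earlier exchange of ethyl and 2-fluorophenyl could not be ranked, whereas compound 3 stands clear of both compound 1 and compound 2. The evidence at hand offers no explanation for this rise.

Since the step from compound 2 to compound 3 both removes the fluorine and brings in the ring nitrogen, the two changes remain unseparated. As far as these compounds go, an unsubstituted phenyl or a pyrimidin-2-yl at the same place would help to separate them, and whether the rise would carry over to either group remains open.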